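This account rests on a few compounds, and the source may have more. Where it says the series, first, only, none or still open, it means among the compounds named here.

For the measured compounds named here, in an in vitro ADME assay on microsomes from liver (Homo sapiens) for metabolic stability, tested at 5 uM (a higher number here means that the compound lasts longer, a lower number that the compound disappears faster), compound 1 `CC(C)CCn1nc(-c2cccs2)c(O)c(C2=NS(=O)(=O)c3cc(O)ccc3N2)c1=O` gives 0.0933 h, and compound 2 `CC(C)CCn1nc(-c2cccs2)c(O)c(C2=NS(=O)(=O)c3cc(C4CCCC4=O)ccc3N2)c1=O` gives 0.733 h, the higher of the two numbers measured so far. Going by the values given here, the one measured step, a 7.9-fold higher number from compound 1 to compound 2 (0.90 log units; beyond the scatter), shows that what sits on this aromatic carbon can move the half-life by a clearly visible amount. Compound 3 `CC(C)CCn1nc(-c2cccs2)c(O)c(C2=NS(=O)(=O)c3cc(-c4cnoc4)ccc3N2)c1=O` has not yet been measured; it differs from compound 2 in one spot: 1,2-oxazol-4-yl in place of 2-oxocyclopentyl on an aromatic carbon. Among the compounds with values here, no measured pair swaps the 2-oxocyclopentyl for an aromatic ring, so the measured step says only that this carbon matters, not in which direction this new group will pull. Compound 3 is therefore expected to fall between the two measured numbers, closer to compound 2, an expected step of a 1.8-fold lower number from compound 2 to compound 3 (0.26 log units; within the scatter). The estimate for compound 3 in this assay is 0.4 h, with a range from 0.15 h to 1.1 h.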

Compound 3, half-life: 0.5 h
The estimate for compound 3 lay 1.3-fold (0.10 log units) below the measured number; measured number inside the range.
By their numbers in this assay, from the lowest: compound 1; then compounds 3 and 2 (each within the scatter of the next).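

In this assay the swap of 2-oxocyclopentyl for 1,2-oxazol-4-yl on this aromatic carbon is a 1.5-fold lower number from compound 2 to compound 3 (0.17 log units; within the scatter) and so does not separate the two groups, although one is a non-aromatic ring of carbon only and the other an aromatic ring with 2 hetero atoms. Measured against hydroxy, the 1,2-oxazol-4-yl gives a 5.4-fold higher number from compound 1 to compound 3 (0.73 log units; beyond the scatter) and thus joins the 2-oxocyclopentyl in standing clear of compound 1, so the longer half-life at this place is not tied to one ring type. Nothing available explains why these two rings behave alike here.

On these data alone, whether a five-membered ring is needed at all remains open. An amine, a carboxylic acid, a plain butyl chain or a six-membered phenyl ring on this carbon would show how far the pattern reaches.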